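A few compounds are considered here, and "the series" means these few. Any claim that something is new, unique, unknown or untested is made for them only; others in the source may bear on it.

Compound 1 `O=C(Nc1ccc(Cl)cc1)N[C@H]1CC[C@H](Oc2ccc(F)cc2)CC1`: in a functional assay on CRL2813 cells (Homo sapiens) for cytotoxicity, read by sulforhodamine B assay, with a stated time of 5 days (a higher number here means a weaker inhibitor, a lower number a stronger inhibitor), compound 1 gives > 20000 nM, which is a limit of the assay and not a number.
Compound 2 `Cc1cccc(NC(=O)N[C@H]2CC[C@H](Oc3ccc(F)cc3)CC2)c1`: in this assay compound 2 gives 14400 nM.
Compound 3 `O=C(Nc1cccc(Cl)c1)N[C@H]1CC[C@H](Oc2ccc(F)cc2)CC1`: in this assay compound 3 gives 5900 nM.

Among the two numbers, compound 3 holds the lower one, with compound 2 as its nearest neighbour, as a 2.4-fold lower number from compound 2 to compound 3 (0.39 log units; beyond the scatter) shows. Compound 4 `O=C(Nc1cccc([N+](=O)[O-])c1)N[C@H]1CC[C@H](Oc2ccc(F)cc2)CC1` differs from compound 3 in a single place: nitro in place of chloro on an aromatic carbon. Among the compounds with values here, no measured step swaps a chloro for a nitro, so the guidance is indirect. Within the data shown here, two measured steps touch the same ring: a 2.4-fold lower number from compound 2 to compound 3 (0.39 log units; beyond the scatter), where a chloro replaced a methyl, and an at least 3.3-fold lower number from compound 1 to compound 3 (0.53 log units; beyond the scatter), where the chlorophenyl changed from the 4- to the 3-substituted form. Both were modest at most, and all three measured compounds sit in one broad band. The nitro brings two hydrogen-bond acceptors where the chloro brought none, so a shift cannot be ruled out. The expected step is therefore a 1.2-fold higher number from compound 3 to compound 4 (0.07 log units; within the scatter) in this assay, small and of uncertain direction. Compound 4 is expected to give about 7000 nM, estimated between 2500 nM and 20000 nM.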

Compound 4, half-maximal inhibitory concentration: 6700 nM
Estimate against measurement, compound 4: 1.0-fold (0.02 log units) above; the measured number falls inside the stated range.
By their numbers in this assay, from the lowest: compounds 3 and 4 (each within the scatter of the next); then compound 2. At a limit, above all of these: compound 1.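

In this assay, exchanging 3-chlorophenyl for 3-nitrophenyl gives two compounds that cannot be told apart, with a 1.1-fold higher number from compound 3 to compound 4 (0.06 log units; within the scatter), even though nitro enters with 3 heavy atoms and 2 hydrogen-bond acceptors where chloro had 1 heavy atom and no acceptor. Nitro also matches chloro in its comparison with methyl at this place, with a 2.1-fold lower number from compound 2 to compound 4 (0.33 log units; beyond the scatter), and in its comparison with the 4-chlorophenyl form, with an at least 2.9-fold lower number from compound 1 to compound 4 (0.47 log units; beyond the scatter). Compound 1 stands at a limit of the assay and not at a number, so this last step gives only a floor: the limit of > 20000 nM in this assay, at which 1 of the 4 values shown sits.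

What an amine or a carboxylic acid would give at this same place stays open, since the three groups shown here, chloro, nitro and methyl, cover only a small part of what could sit on this ring. As far as these compounds go, it also stays open whether a 4-nitrophenyl group would track the 4-chlorophenyl group of compound 1, and whether the likeness of compound 3 and compound 4 would hold on a core other than the one shared here.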